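This account rests on a few compounds, and the source may have more. Where it says the series, first, only, none or still open, it means among the compounds named here.

Compound 1 `CCN(CC)C(=O)c1nc2ccccc2n1Cc1ccc(Cl)cc1`: 2570 nM
Compound 2 `CCN(CC)C(=O)c1cc2cc(C)ccc2n1Cc1ccc(OCc2ccccc2)cc1`: > 10000 nM

Both numbers come from an assay on HEK293 cells for displacement of a labelled ligand from Translocator protein (Homo sapiens), read by scintillation counting, with a stated time of 90 min; a higher number here means a weaker inhibitor, a lower number a stronger inhibitor. For compound 2 the result is a limit of the assay rather than a number, and it sits at the limit of > 10000 nM in this assay, at which 1 of the 2 values shown sits. Compound 3 `CCN(CC)C(=O)c1cc2cc(C)ccc2n1Cc1ccc(O)cc1` has not yet been measured; it differs from compound 2 by hydrogen in place of benzyl on an oxygen on an aromatic ring. Among the measured compounds shown here, no step between two measured compounds is available to guide the expectation, so the size of this change has to be judged from the pair alone. In this assay the expected step is an at least 2.0-fold lower number from compound 2 to compound 3 (0.30 log units; that floor lies within the scatter), in the direction of stronger binding, with wide uncertainty since the starting point is only a limit. Compound 3 is therefore estimated at 5000 nM, expected to fall between 1000 nM and 20000 nM.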

Compound 3, inhibition constant: > 10000 nM
Compound 3 gave a limit, no number; the forecaster's own chance of this, stated with the estimate: 40%; middle value at least 2.0-fold (0.30 log units) from the limit.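

Compound 2 and compound 3 both give only a limit of the assay, not a number, so the step from benzyloxy to hydroxy cannot be read: the limit of > 10000 nM in this assay, at which 2 of the 3 values shown sit.

On these data alone, how strongly either compound binds, and whether this change shifts binding at all, remains open.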